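Clearance notes on the amine-substituent series

The compounds below may be only part of what the source reports. "The series", "measured", "known", "first", "only" and "open" are said of these compounds alone.

Measured so far in an ADME assay on cells (Hepatocyte, Rattus norvegicus) for metabolic stability; a higher number here means faster removal of the compound, a lower number slower removal:
compound 1, `CCN(CC)CCN(C)c1ccc(Nc2cc(NC3CC3)n3ncc(C#N)c3n2)cc1NC(C)=O`, gives 27 uL/min.
compound 2, `CC(=O)Nc1cc(Nc2cc(NC3CC3)n3ncc(C#N)c3n2)ccc1NCCCO`, gives 17 uL/min.
compound 3, `CC(=O)Nc1cc(Nc2cc(NC3CC3)n3ncc(C#N)c3n2)ccc1N1CC[C@H](N)C1`, gives only a limit of the assay, < 1 uL/min.

On the numbers shown, compound 1 stands highest of the two numbers, with compound 2 nearest: a 1.6-fold lower number from compound 1 to compound 2 (0.20 log units; within the scatter). Compound 3 sits at the limit described in the limit of < 1 uL/min in this assay, at which 1 of the 3 values shown sits.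

Compound 4, `CC(=O)Nc1cc(Nc2cc(NC3CC3)n3ncc(C#N)c3n2)ccc1N1CCC[C@@H](N(C)C)C1`, has not been measured. It differs from compound 1 as follows: a group of 9 heavy atoms (7 carbon, 2 nitrogen; one six-membered non-aromatic ring with 1 hetero atom) in place of a group of 9 heavy atoms (7 carbon, 2 nitrogen; no ring), on an aromatic carbon.

Among the measured compounds shown here, two measured steps bear on this. The step from compound 1 to the other acyclic group was small: a 1.6-fold lower number from compound 1 to compound 2 (0.20 log units; within the scatter). The step to the ring-bearing group was large: an at least 27-fold lower number from compound 1 to compound 3 (1.43 log units; beyond the scatter), as was an at least 17-fold lower number from compound 2 to compound 3 (1.23 log units; beyond the scatter). Compound 4 also carries a ring-bearing group on that aromatic carbon, so a drop in this assay is expected, though the closed structure in compound 3 is not the same group, so less certainty attaches to its size. The expected step is a 5.4-fold lower number from compound 1 to compound 4 (0.73 log units; beyond the scatter). Compound 4 is estimated at 5 uL/min, within 1 uL/min to 20 uL/min.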

Compound 4, intrinsic clearance in a liver preparation (reported as CLH), per the amount of preparation that the assay uses: < 1 uL/min
Compound 4: only a limit was reported; the forecaster's own chance of this, stated with the estimate: 20%; middle value at least 5.0-fold (0.69 log units) from the limit.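

In this assay compound 4 gives a limit and not a number, making it the second ring-bearing group on this aromatic carbon, ortho to an acetamido group, to do so: the limit of < 1 uL/min in this assay, at which 2 of the 4 values shown sit.

The change keeps the heavy-atom count and the hydrogen-bond donor and acceptor counts of (2-(diethylamino)ethyl)(methyl)amino, yet gives an at least 27-fold lower number from compound 1 to compound 4 (1.43 log units; beyond the scatter), and the other acyclic group gives an at least 17-fold lower number from compound 2 to compound 4 (1.23 log units; beyond the scatter). Across the compounds shown, both ring-bearing groups sit at the limit while both acyclic groups give numbers, with no compound against this, and the step from compound 3 to compound 4 cannot be read, both values being limits.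

Any ranking of the five-membered and six-membered rings, or of the two stereocentres, stays open. A morpholine or an unsubstituted piperidine on this carbon would test whether the ring alone gives this result without the amine substituent.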